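Methoxy for Methylsulfanyl in a Pair of Close Values

The source may report more compounds than this note shows. Statements on the series, on what has been measured and on what is new or still open speak of the compounds shown alone.

For the measured compounds named here, in an ADME assay on HaCaT cells (Homo sapiens) for cytotoxicity, read by MTT assay, with a stated time of 48 h (a higher number here means a weaker inhibitor, a lower number a stronger inhibitor), compound 1 `COc1cc(-c2ocnc2-c2cc(Br)c(OC)c(OC)c2)ccc1SC` gives 260 nM and compound 2 `COc1ccc(-c2ocnc2-c2cc(OC)c(SC)c(OC)c2)cc1O` gives 320 nM as the only two numbers so far. They lie within the scatter of each other, so compound 1 stands level with compound 2 and not apart from it.

Compound 3 `COc1ccc(-c2ocnc2-c2cc(Br)c(OC)c(OC)c2)cc1OC` has not yet been measured. Its change from compound 1 is methoxy in place of methylsulfanyl on an aromatic carbon and it amounts to methoxy in place of methylsulfanyl on an aromatic carbon, ortho to a methoxy group and para to a large group.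

Going by the values given here, no measured pair isolates this swap, so the data offer no direct guide to its size. Compound 1 at 260 nM and compound 2 at 320 nM differ in several places and still sit within the scatter of each other, so no step beyond the scatter is expected in either direction. The estimated step is a 1.3-fold higher number from compound 1 to compound 3 (0.13 log units; within the scatter) and it is expected to stay inside that scatter. In this assay compound 3 is estimated at 350 nM with an expected range from 100 nM to 1500 nM once measured.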

Compound 3, half-maximal inhibitory concentration: 10100 nM
Estimate against measurement, compound 3: 29-fold (1.46 log units) below; the whole stated range lies below it.
By their numbers in this assay, from the lowest: compounds 1 and 2 (each within the scatter of the next); then compound 3.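

In this assay, the exchange of methylsulfanyl for methoxy on this aromatic carbon, ortho to a methoxy group and para to a large group, proves to be a large change: the step is a 39-fold higher number from compound 1 to compound 3 (1.59 log units; beyond the scatter). The counts of heavy atoms, hydrogen-bond donors and hydrogen-bond acceptors are the same for the leaving and the entering group, so these counts do not separate the two compounds, while the single exchange of sulfur for oxygen within the group does, and this place on the core of compound 1 is shown to respond strongly to it. The earlier compounds could not show this, since they differ from each other in several places, and no measurement available here accounts for the size of the step.

The compounds shown leave open how other groups on this carbon would behave, such as ethylsulfanyl, a chlorine atom or an amine, and so whether methylsulfanyl itself is special or methoxy is unusually poor here. They also leave open whether the same exchange would give a step of this size in compounds without the bromine atom on the other aromatic ring.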